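The source may report more compounds than this note shows. Statements on the series, on what has been measured and on what is new or still open speak of the compounds shown alone.

Four related compounds are compared here. Compound 1 has the structure `COc1cc(-c2cc(/C=C/C(=O)c3ccc(N)cc3)[nH]n2)cc(OC)c1OC` and compound 2 has the structure `COc1ccc(-c2cc(/C=C/C(=O)c3ccc(N)cc3)[nH]n2)cc1OC`. In a functional assay on M14 cells (Homo sapiens) for inhibition, read by sulforhodamine B assay, with a stated time of 48 h (on this read-out lower numbers stand for stronger inhibition of growth and higher numbers for weaker inhibition of growth), compound 1 gives 3860 nM, and in this assay compound 2 gives 5110 nM. The difference between them is hydrogen in place of methoxy on an aromatic carbon and it produced a 1.3-fold higher number from compound 1 to compound 2 (0.12 log units; within the scatter).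

Compound 3 has the structure `COc1cc(C(=O)/C=C/c2cc(-c3cc(OC)c(OC)c(OC)c3)n[nH]2)cc(OC)c1OC`. In this assay compound 3 gives 3320 nM, a number close to that of compound 1 and of compound 2. The difference between the core of compound 3 and the core of compound 1 is not broken down here.

Compound 4, with the structure `COc1ccc(-c2cc(/C=C/C(=O)c3cc(OC)c(OC)c(OC)c3)[nH]n2)cc1OC`, has not yet been measured. Compound 4 differs from compound 3 by hydrogen in place of methoxy on an aromatic carbon, the same change as from compound 1 to compound 2, made around the same kind of place. Because the earlier step gave a 1.3-fold higher number from compound 1 to compound 2 (0.12 log units; within the scatter), the step from compound 3 to compound 4 is expected to be a 1.3-fold higher number from compound 3 to compound 4 (0.11 log units; within the scatter). On that basis compound 4 is estimated to give 4300 nM in this assay, with a likely range from 2300 nM to 8500 nM.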

Compound 4, concentration for total growth inhibition: 3690 nM
For compound 4 the middle estimate is 1.2-fold (0.07 log units) above the measured one, within the range that was stated.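

In this assay the swap of methoxy for hydrogen gives a 1.1-fold higher number from compound 3 to compound 4 (0.05 log units; within the scatter), so on the core of compound 3 this change again produces no readable difference. Set side by side, the two cores agree: the same change on two cores in this assay, a 1.3-fold higher number (0.12 log units; within the scatter) from compound 1 to compound 2 and a 1.1-fold higher number (0.05 log units; within the scatter) from compound 3 to compound 4, 1.2-fold (0.08 log units) apart, within the scatter of two such steps. What carries over is therefore only a step too small to separate from the noise of repeated measurements; this does not show that the change has a real effect of a shared size on both cores, and two cores cannot show how it would behave on a third.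

The compounds shown carry only methoxy or hydrogen at this place on the ring, so they say nothing about how other groups would behave there. As far as these compounds go, whether a hydroxyl group, a carboxylic acid or a longer chain such as ethoxy at that place would give a step beyond the scatter remains open.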